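Aryl swap on the ring amine nitrogen: compound 1 to 4

The source may hold more compounds than are shown below. What is called first, only, known or untested is meant among the compounds shown, and "the series" means these compounds.

Three compounds of this series have numbers in an assay on HEK293 cells for inhibition of Voltage-dependent T-type calcium channel subunit alpha-1G (Homo sapiens), read by fluorescence, tested at 10 uM; on this read-out higher numbers stand for more inhibition at the one concentration tested (going by the name of the read-out) and lower numbers for less inhibition. Compound 1 `CCCc1nc(-c2ccccc2)c(CNCCN2CCN(c3ccc(Cl)cc3)CC2)o1` gives 55.8%, the highest of the three. Compound 2 `CCCc1nc(-c2ccccc2)c(CNCCCN2CCN(c3cccc(C(F)(F)F)c3)CC2)o1` gives 51.6%, which sits within the scatter of compound 1. Compound 3 `CCCc1nc(-c2ccccc2)c(CNCCCN2CCN(c3ccccc3)CC2)o1` gives 43.7%, beyond the scatter below compound 1. Among the measured compounds shown here, the only single-point step among them, a number 7.9 percentage points lower from compound 2 to compound 3 (within the scatter), shows that removing a trifluoromethyl from the aromatic carbon leaves the read-out within the scatter.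

Compound 4 `CCCc1nc(-c2ccccc2)c(CNCCN2CCN(c3cccc(C)c3C)CC2)o1` differs from compound 1 by 2,3-dimethylphenyl in place of 4-chlorophenyl on an amine nitrogen in a ring. For the measured compounds named here, no measured step covers a 2,3-dimethylphenyl, but the one step that does alter the aryl group on this ring nitrogen stays within the scatter, and all three measured aryl variants fall in a narrow band. The step is therefore expected to be small, with no clear direction beyond the scatter, estimated as a number 5.8 percentage points lower from compound 1 to compound 4 (within the scatter). Compound 4 is expected to give 50%, within 35% to 65%.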

Compound 4, a percentage reported as inhibition, at one concentration (the size of the read-out at that concentration, not a potency): 66.7%
Beside the measured number, compound 4's estimate is 16.7 percentage points below it, outside the stated range (above it).
By their numbers in this assay, from the lowest: compounds 3, 2 and 1 (each within the scatter of the next, the first and the last beyond it); then compound 4.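

The aryl group on the ring amine nitrogen can shift the number in this assay beyond the scatter: the step is a number 10.9 percentage points higher from compound 1 to compound 4 (beyond the scatter), with 2,3-dimethylphenyl in place of 4-chlorophenyl. Among the compounds shown here, the earlier aryl step, a number 7.9 percentage points lower from compound 2 to compound 3 (within the scatter), stayed within the scatter, so this pair is the first change on that aryl group to read beyond it, though the step is modest and rests on one pair. Nothing at hand accounts for the higher number with 2,3-dimethylphenyl.

From the compounds shown here alone, whether one methyl group alone would carry this step stays open, as does the reading of a pyridine ring on the same nitrogen. Also open, going by these compounds, is whether 2,3-dimethylphenyl would hold its number on the longer chain found in compound 2 and compound 3.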